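Thiazolyl in place of pyridyl on the piperazine nitrogen

The source may hold more compounds than are shown below. What is called first, only, known or untested is meant among the compounds shown, and "the series" means these compounds.

Working notes on the series. Compound 1 `O=C(CN1CCN(c2ccncc2)CC1)Nc1nc2c(s1)CCCC2` is the lower of the two compounds measured in a physicochemical assay for lipophilicity, in phosphate buffer, measured as octanol-water partition, at pH 7.4; a higher number here means a more lipophilic compound, a lower number a more polar compound: in that assay compound 1 gives 2. Compound 2 `Cc1nc(NC(=O)CN2CCN(c3ccc(F)cc3)CC2)sc1C`, on a different core, gives 3.7 in this assay, a gap beyond the usual scatter, so compound 1 stands at the bottom of what has been measured. Compound 3 `O=C(CN1CCN(c2nccs2)CC1)Nc1nc2c(s1)CCCC2` has not been measured in this assay. It keeps the core and the amide linkage of compound 1 and differs in one place: 1,3-thiazol-2-yl in place of pyridin-4-yl on an amine nitrogen in a ring. Among the compounds with values here, no pair of measured compounds shows this same change, so no measured step can be borrowed for it. The expectation for this assay is a step of a number 1.10 log units higher from compound 1 to compound 3 (beyond the scatter), upward and beyond the scatter. Compound 3 is estimated at 3.1, with a range from 2.5 to 3.7.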

Compound 3, distribution coefficient: 3.8
Compound 3: the middle estimate sits 0.70 log units below what was measured, and the stated range ends below it.
By their numbers in this assay, from the lowest: compound 1; then compounds 2 and 3 (each within the scatter of the next).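

On the shared core with the amide linkage kept, 1,3-thiazol-2-yl in place of pyridin-4-yl on an amine nitrogen in a ring gives in this assay a step of a number 1.80 log units higher from compound 1 to compound 3 (beyond the scatter) on its own. The group on this nitrogen can therefore move the read-out well beyond the scatter, something the earlier pair could not show, as compound 1 and compound 2 differ in more than one place. Nothing measured in this series accounts for the size of this step.

This single pair changes ring size, hetero atoms and the place of the ring nitrogen together, leaving their shares of the step open. Also open, as far as these compounds go, are how a phenyl or a 1,3-oxazol-2-yl on the same nitrogen would read, and whether the step holds on the core of compound 2.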